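This account rests on a few compounds, and the source may have more. Where it says the series, first, only, none or still open, it means among the compounds named here.

Compound 2 `C=CCc1cc(C(C)=O)c(O)cc1OCCCCCCCCC#N` and compound 1 `C=CCc1cc(C(C)=O)c(O)cc1OCCCCCCCC#N` share one core and differ only at the far end of a chain that hangs from an oxygen on the aromatic ring. In an assay on isolated protein for inhibition of leukotriene B4 receptor 1 (Homo sapiens), tested at 10 uM (a lower number here means less inhibition, a higher number more inhibition at the concentration tested (going by the name of the read-out)), compound 1 gives 88%, and compound 2 gives 86%. Within the data shown here, the only step between measured compounds is a number 2 percentage points lower from compound 1 to compound 2 (within the scatter), so the two numbers sit within the scatter of each other and neither compound can be said to give the higher number.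

Compound 3 `C=CCc1cc(C(C)=O)c(O)cc1OCCCC` has not been measured in this assay. Its difference from compound 2 is hydrogen in place of 4-cyanobutyl on a saturated chain carbon, four bonds along the chain from an oxygen on an aromatic ring. Among the measured compounds shown here, this removes the whole outer part of the chain, including the nitrile, a change that no measured step covers: the step from compound 1 to compound 2 only added one chain carbon and left the nitrile in place. With so much of the chain gone, a clear drop in the number is expected rather than a small shift, but the numbers give no firm anchor for its size. The expected step from compound 2 to compound 3 in this assay is a number 31 percentage points lower from compound 2 to compound 3 (beyond the scatter). Compound 3 is therefore estimated at 55%, within a range from 20% to 85%.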

Compound 3, a percentage reported as inhibition, at one concentration (the size of the read-out at that concentration, not a potency): 32%
Compound 3: middle estimate off by 23 percentage points, on the high side; measured number inside the range.
By their numbers in this assay, from the lowest: compound 3; then compounds 2 and 1 (each within the scatter of the next).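

Removing the outer part of the chain has a large effect in this assay. Replacing 4-cyanobutyl with hydrogen gives a number 54 percentage points lower from compound 2 to compound 3 (beyond the scatter), and replacing 3-cyanopropyl with hydrogen at the same place gives a number 56 percentage points lower from compound 1 to compound 3 (beyond the scatter), so this position, where the earlier pair differed only within the scatter, does respond once the nitrile and the outer chain are gone together. Even so, compound 3 still gives 32%, so some inhibition at the concentration tested remains without that outer part, and nothing available here explains the fall.

The compounds shown leave open whether the drop follows the loss of the nitrile, the loss of chain length, or both, as the two leave together in each step. A chain of similar length ending in a plain methyl would separate these two changes, while a chain ending in an amine or a carboxylic acid, or a longer chain, would show how much variation this end of the molecule allows.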